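A few compounds are considered here, and "the series" means these few. Any claim that something is new, unique, unknown or untested is made for them only; others in the source may bear on it.

In an assay for binding affinity to dual specificity mitogen-activated protein kinase kinase 4 (Homo sapiens), read by KINOMEscan, tested at 100 nM (on this read-out lower numbers stand for a stronger effect and higher numbers for a weaker effect at the one concentration tested), compound 3 `CCCS(=O)(=O)Nc1ccc(F)c(C(=O)c2n[nH]c3ncc(-c4ccc(F)cc4C)cc23)c1F` gives 14%, the second highest of the three numbers measured. Compound 1 `CCCS(=O)(=O)Nc1ccc(F)c(C(=O)c2n[nH]c3ncc(-c4cccc(O)c4)cc23)c1F` gives 2.2%, and compound 2 `CCCS(=O)(=O)Nc1ccc(F)c(C(=O)c2n[nH]c3ncc(-c4cc(Cl)cc(Cl)c4)cc23)c1F` gives 73%. Compound 4 `CCCS(=O)(=O)Nc1ccc(F)c(C(=O)c2n[nH]c3ncc(-c4ccc(C(N)=O)cc4)cc23)c1F` differs from compound 3 at the same ring that varies across these three: 4-carbamoylphenyl in place of 4-fluoro-2-methylphenyl on an aromatic carbon. Going by the values given here, two measured steps bear on this position, a number 11.8 percentage points higher from compound 1 to compound 3 (beyond the scatter) and a number 59 percentage points lower from compound 2 to compound 3 (beyond the scatter), so changes here have moved the read-out by modest to large amounts in either direction. The entering group carries one hydrogen-bond donor and one acceptor, and the only prior ring with such features, on compound 1, gave the lowest number. A modest decrease is therefore expected, a number 8 percentage points lower from compound 3 to compound 4 (within the scatter), and compound 4 is estimated at 6%, with a range of 1% to 35%.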

Compound 4, a percentage reported as activity, at one concentration (the size of the read-out at that concentration, not a potency): 0.15%
Beside the measured number, compound 4's estimate is 5.9 percentage points above it; the whole stated range lies above it.
By their numbers in this assay, from the lowest: compounds 4 and 1 (each within the scatter of the next); then compound 3; then compound 2.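

In this assay putting 4-carbamoylphenyl in place of 4-fluoro-2-methylphenyl gives a number 13.9 percentage points lower from compound 3 to compound 4 (beyond the scatter) and putting it in place of 3,5-dichlorophenyl gives a number 72.9 percentage points lower from compound 2 to compound 4 (beyond the scatter) so a second ring now reaches the strong end of the read-out. Against 3-hydroxyphenyl the change gives a number 2.1 percentage points lower from compound 1 to compound 4 (within the scatter) so two differently substituted rings sit together at that end. Nothing available explains why these two rings behave alike. Still open, as far as these compounds go, is how much depends on the carbamoyl group itself. A carboxylic acid or a methyl amide in its place would test this.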